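Aryl for Alkyl on the Alkyne: Expecting Compound 3

The compounds below may be only part of what the source reports. "The series", "measured", "known", "first", "only" and "open" are said of these compounds alone.

Of the compounds shown here, two have been measured in a functional assay on CCRF-CEM cells (Homo sapiens) for antiproliferative activity, read by MTT assay, with a stated time of 3 days; on this read-out lower numbers stand for stronger inhibition and higher numbers for weaker inhibition. Compound 1 `CCCCCCCCC#Cc1cn(C/C=C\CN2C(=O)c3ccccc3C2=O)c(=O)[nH]c1=O` gives 39000 nM, the lowest of the two numbers. Compound 2 `CCCCC#Cc1cn(C/C=C/CN2C(=O)c3ccccc3C2=O)c(=O)[nH]c1=O` gives 192000 nM, a higher number than compound 1 beyond the usual scatter; these two differ in more than one place, so their gap cannot be assigned to any single change. Compound 3 `CCCCc1ccc(C#Cc2cn(C/C=C\CN3C(=O)c4ccccc4C3=O)c(=O)[nH]c2=O)cc1` has not yet been measured in this assay. It differs from compound 1 by 4-butylphenyl in place of octyl on a triple-bonded carbon, an open chain giving way to a ring-bearing group. Going by the values given here, no measured step follows this kind of change, so the expectation rests on compound 1 alone. The step of a 1.3-fold lower number from compound 1 to compound 3 (0.11 log units; within the scatter) in this assay is expected to be small, in either direction and within the scatter. Compound 3 is therefore estimated at 30000 nM in this assay, with a range from 8000 nM to 120000 nM.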

Compound 3, half-maximal inhibitory concentration: 23000 nM
Compound 3: middle estimate off by 1.3-fold (0.12 log units), on the high side; low and high end bracket the measured number.
By their numbers in this assay, from the lowest: compounds 3 and 1 (each within the scatter of the next); then compound 2.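

In this assay, 4-butylphenyl in place of octyl on a triple-bonded carbon gives a 1.7-fold lower number from compound 1 to compound 3 (0.23 log units; within the scatter) and so stays within the scatter. Going by these compounds alone, the earlier pair differed in more than one place, so this is the only step that can be read here, and it shows that an open chain on this carbon can give way to a group bearing a six-membered aromatic ring without a shift beyond the scatter. Nothing at hand explains why the two groups read alike.

From the compounds shown here alone, it remains open whether the ring or the butyl chain on it matters more, which a plain phenyl or a longer chain on the ring could address. An amine or a carboxylic acid on the ring would test whether this carbon also tolerates groups with hydrogen-bond donors or acceptors.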